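A few compounds are considered here, and "the series" means these few. Any claim that something is new, unique, unknown or untested is made for them only; others in the source may bear on it.

Compounds measured in an ADME assay on MRC5 cells (Homo sapiens), read by MTT assay, with a stated time of 72 h; a higher number here means a weaker inhibitor, a lower number a stronger inhibitor:

Compound 1, `COc1ncnc2c1c(-c1cc3ccccc3o1)cn2[C@@H]1O[C@H](CO)[C@@H](O)[C@H]1O`, gives 65600 nM.
Compound 2, `Nc1nc(N)c2c(-c3ccccc3)cn([C@@H]3O[C@H](CO)[C@@H](O)[C@H]3O)c2n1`, gives only a limit of the assay, > 100000 nM.
Compound 3, `Cc1nc(N)c2c(-c3ccccc3)cn([C@@H]3O[C@H](CO)[C@@H](O)[C@H]3O)c2n1`, likewise gives only a limit of the assay, > 100000 nM.

Among the measured compounds shown here, compound 3 therefore stands at the limit rather than at a number, and it shares that limit with compound 2; the one step between measured compounds, a step that the two limits leave unreadable from compound 2 to compound 3, is unreadable for that reason, as the limit of > 100000 nM in this assay, at which 2 of the 3 values shown sit, records. Compound 4, `Cc1nc(N)c2c(-c3ccco3)cn([C@@H]3O[C@H](CO)[C@@H](O)[C@H]3O)c2n1`, differs from compound 3 by furan-2-yl in place of phenyl on an aromatic carbon. For the measured compounds named here, no measured step touches this change, and the only numbered value, that of compound 1, belongs to a compound differing in more than one place. The step of a number no higher from compound 3 to compound 4 (the limit leaves the size open) is thus expected to be small or none beyond the scatter. Compound 4 is estimated at 100000 nM, within 40000 nM to 300000 nM, with a further limit the likelier outcome.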

Compound 4, half-maximal inhibitory concentration: > 100000 nM
Compound 4 ended at the assay's limit (the forecaster's own chance of this, stated with the estimate: 65%); the middle value sits exactly at the limit.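

No step can be read from compound 3 to compound 4, since both values are limits and not numbers: the limit of > 100000 nM in this assay, at which 3 of the 4 values shown sit.
As far as these compounds go, how furan-2-yl compares with phenyl on the shared core in this assay remains open.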